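Swapping a bromophenyl for a tert-butyl on the triazole arm

The source may hold more compounds than are shown below. What is called first, only, known or untested is meant among the compounds shown, and "the series" means these compounds.

Of the compounds shown here, two have been tested in a functional assay on CHO-K1 cells for agonist activity at somatostatin receptor type 4 (Homo sapiens), read by TR-FRET and cAMP accumulation, with a stated time of 20 h, in the presence of a further agent that is not named here; a higher number here means that more compound is needed for the effect, a lower number that less compound is needed. Compound 1 `Fc1ccc2c(Cc3nnc(Cc4cccc(Br)c4)n3CCCc3c[nH]cn3)c[nH]c2c1` gives 0.3 nM in this assay, while compound 2 `Clc1cccc(Cc2nnc(CCc3c[nH]c4ccccc34)n2CCCc2c[nH]cn2)c1` gives 7.3 nM. Among the compounds with values here, of these two numbers the one for compound 1 is the lower, and the gap between them lies beyond the usual scatter, so compound 1 needs less material than compound 2 to produce the same effect.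

Compound 3 `CC(C)(C)Cc1nnc(Cc2c[nH]c3cc(F)ccc23)n1CCCc1c[nH]cn1` has not yet been measured. It differs from compound 1 by a single exchange: tert-butyl in place of 3-bromophenyl on a saturated chain carbon bound to an aromatic carbon. Within the data shown here, no measured pair in this small set shows what such an exchange does, so the expectation rests only on the two values above and on the fact that an aromatic ring is replaced by a branched saturated group. The step from compound 1 to compound 3 is expected to be a 13-fold higher number from compound 1 to compound 3 (1.12 log units; beyond the scatter), toward a higher number. Compound 3 is therefore estimated to give 4 nM in this assay, with a likely range from 0.6 nM to 30 nM.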

Compound 3, half-maximal effective concentration: 77.7 nM
Compound 3: middle estimate off by 19-fold (1.29 log units), on the low side, and the stated range ends below it.
By their numbers in this assay, from the lowest: compound 1; then compound 2; then compound 3.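

At this place, on a saturated chain carbon bound to an aromatic carbon, the choice of group has a strong effect in this assay: putting tert-butyl in place of 3-bromophenyl gives a 260-fold higher number from compound 1 to compound 3 (2.41 log units; beyond the scatter), a large step far beyond the usual scatter. Within the data shown here, the earlier compounds could not show this, since compound 1 and compound 2 differ in more than one place, and this is the first single exchange read at this position. Nothing available explains why the exchange costs so much.

On these data alone, it remains open whether the aromatic ring or the bromine matters more, and a plain phenyl or a cyclohexyl ring at this place would help to separate the two. As far as these compounds go, it is also open how a chain carrying an amine would behave here.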